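The compounds below may be only part of what the source reports. "The series", "measured", "known", "first", "only" and "open" are said of these compounds alone.

In a functional assay on PC-3 cells (Homo sapiens) for inhibition, read by MTT assay, with a stated time of 48 h (on this read-out higher numbers stand for weaker inhibition and lower numbers for stronger inhibition), compound 1 `COc1ccc(CN(c2cc(OC)c(OC)c(OC)c2)S(=O)(=O)c2ccccc2)cc1` gives > 50000 nM, which is a limit of the assay and not a number. Compound 2 `COc1cc(N(Cc2nc3ccccc3[nH]2)S(=O)(=O)c2ccc(C)cc2)cc(OC)c1OC` gives 3340 nM. Compound 3 `COc1cc(N(Cc2nc3ccccc3[nH]2)S(=O)(=O)c2ccc(F)cc2)cc(OC)c1OC` gives 7990 nM, the higher of the two actual numbers. Compound 4 `COc1cc(N(Cc2nc3ccccc3[nH]2)S(=O)(=O)c2ccccc2Cl)cc(OC)c1OC` follows with 2-chlorophenyl in place of 4-fluorophenyl on a sulfonyl sulfur. Going by the values given here, the one measured step bearing on this group is a 2.4-fold higher number from compound 2 to compound 3 (0.38 log units; beyond the scatter), which is modest but beyond the scatter. A similarly modest change is therefore expected in this assay, with only a weak lean towards a lower number, and the estimated step is a 1.6-fold lower number from compound 3 to compound 4 (0.20 log units; within the scatter). For compound 4 the expected value is 5000 nM, with an estimated range of 1800 nM to 14000 nM.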

Compound 4, half-maximal inhibitory concentration: 34500 nM
For compound 4 the middle estimate is 6.9-fold (0.84 log units) below the measured one; the whole stated range lies below it.
By their numbers in this assay, from the lowest: compound 2; then compound 3; then compound 4. At a limit, above all of these: compound 1.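

Changing the group on the sulfonyl sulfur in this assay can shift the read-out by more than the earlier pair showed (a 4.3-fold higher number from compound 3 to compound 4 (0.64 log units; beyond the scatter)), and the gap widens against the 4-methylphenyl group (a 10-fold higher number from compound 2 to compound 4 (1.01 log units; beyond the scatter)). Among compound 2, compound 3 and compound 4, the 2-chlorophenyl group gives the highest number, so these aryl groups are not interchangeable at this position. Nothing given here accounts for the size of this change.

Still open, going by these compounds, is whether the shift follows the chlorine itself or where it sits on the ring. Also open, on these data alone, is how an amine or a carboxylic acid on that phenyl ring would read.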